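This account rests on a few compounds, and the source may have more. Where it says the series, first, only, none or still open, it means among the compounds named here.

Working notes on the series.

Compound 1 `ClCc1ccccc1Cn1cnc2c(Cl)nc(Cl)nc21` and compound 2 `ClCc1cccc(Cn2cnc3c(Cl)nc(Cl)nc32)c1` share the same atoms joined differently; the difference between the two cores is not broken down here. In a functional assay on KM12 cells (Homo sapiens) for cytotoxicity, read by sulforhodamine B assay, with a stated time of 48 h (on this read-out higher numbers stand for weaker inhibition of growth and lower numbers for stronger inhibition of growth), compound 1 gives 1470 nM, and compound 2 gives 1820 nM; the two values lie within the scatter of each other.

Compound 3 `Nc1nc(Cl)c2ncn(Cc3ccccc3CCl)c2n1` is compound 1 with amino in place of chloro on an aromatic carbon. In this assay compound 3 gives 15500 nM, a step of an 11-fold higher number from compound 1 to compound 3 (1.02 log units; beyond the scatter).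

Compound 4 `Nc1nc(Cl)c2ncn(Cc3cccc(CCl)c3)c2n1` is compound 2 with amino in place of chloro on an aromatic carbon, the same change made on the other core. Because compound 1 to compound 3 gave an 11-fold higher number from compound 1 to compound 3 (1.02 log units; beyond the scatter), a step of similar size is expected from compound 2 to compound 4, a 10-fold higher number from compound 2 to compound 4 (1.02 log units; beyond the scatter). On that basis compound 4 is estimated in this assay at 19000 nM, between 8000 nM and 45000 nM.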

Compound 4, concentration for 50% growth inhibition: 3310 nM
For compound 4 the middle estimate is 5.7-fold (0.76 log units) above the measured one; measured number outside the range, below it.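

Amino in place of chloro on an aromatic carbon does not carry over at one size between the two cores in this assay, where the new step is a 1.8-fold higher number from compound 2 to compound 4 (0.26 log units; within the scatter). Set beside the earlier step, the two differ: the same change on two cores in this assay, an 11-fold higher number (1.02 log units; beyond the scatter) from compound 1 to compound 3 and a 1.8-fold higher number (0.26 log units; within the scatter) from compound 2 to compound 4, 5.8-fold (0.76 log units) apart, beyond the scatter of two such steps. Within these two pairs the size of the step goes with the core, but two pairs give no rule for other cores and do not show what in the cores accounts for the gap.

The compounds shown leave open whether a methylamino or methoxy group at the same place would follow the amino step on either core. They also leave open how a hydroxymethyl group in place of the chloromethyl group would read on either core.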